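The source may report more compounds than this note shows. Statements on the series, on what has been measured and on what is new or still open speak of the compounds shown alone.

Three compounds share one core. Compound 1 `CC1(C)[C@H]2CC[C@]1(C)N(Cc1cn(-c3ccc(Cl)cc3)nn1)C(=O)C2` gives 440 nM in a functional assay on PANC-1 cells (Homo sapiens) for inhibition, read by MTT assay, with a stated time of 24 h; on this read-out higher numbers stand for weaker inhibition and lower numbers for stronger inhibition. Compound 2 `CC1(C)[C@H]2CC[C@]1(C)N(Cc1cn(-c3ccccc3)nn1)C(=O)C2` gives 160 nM in this assay, and compound 3 `CC1(C)[C@H]2CC[C@]1(C)N(Cc1cn(-c3cccc(Br)c3)nn1)C(=O)C2` gives 90 nM in this assay. On these numbers compound 2 stands second highest of the three, nearest to compound 3 with a 1.8-fold lower number from compound 2 to compound 3 (0.25 log units; within the scatter), and furthest from compound 1, which it follows with a 2.8-fold lower number from compound 1 to compound 2 (0.44 log units; beyond the scatter). Compound 4 `CC1(C)[C@H]2CC[C@]1(C)N(Cc1cn(-c3ccc(Br)cc3)nn1)C(=O)C2` differs from compound 2 by bromo in place of hydrogen on an aromatic carbon. Going by the values given here, two measured steps bear on this change. The step of a 1.8-fold lower number from compound 2 to compound 3 (0.25 log units; within the scatter) also puts a bromo on an aromatic carbon of the phenyl and stays within the scatter. The step of a 2.8-fold lower number from compound 1 to compound 2 (0.44 log units; beyond the scatter) removes a halogen from that phenyl; read backwards, it suggests that a halogen there raises the number modestly. Compound 4 is therefore expected to show a modest step toward a higher number, a 1.9-fold higher number from compound 2 to compound 4 (0.27 log units; within the scatter), though it may stay within the scatter. The estimate for compound 4 is 300 nM, with a range from 120 nM to 750 nM.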

Compound 4, half-maximal inhibitory concentration: 200 nM
Estimate against measurement, compound 4: 1.5-fold (0.18 log units) above; the measured number falls inside the stated range.
By their numbers in this assay, from the lowest: compounds 3, 2 and 4 (each within the scatter of the next, the first and the last beyond it); then compound 1.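

In this assay, bromo para to a large group on the phenyl stays within the scatter of the unsubstituted compound (a 1.3-fold higher number from compound 2 to compound 4 (0.10 log units; within the scatter)), so the modest rise seen with chloro at this place does not carry over to every halogen. The identity of the halogen matters here, with a 2.2-fold lower number from compound 1 to compound 4 (0.34 log units; beyond the scatter) when bromo replaces chloro. Where the bromo sits also matters: neither bromo compound leaves the scatter of compound 2, yet the two differ beyond it, with a 2.2-fold higher number from compound 3 to compound 4 (0.35 log units; beyond the scatter) when 4-bromophenyl replaces 3-bromophenyl.

No measurement given here accounts for these steps. From the compounds shown here alone, it remains open whether an amine, a carboxylic acid or a methoxy group at this place on the phenyl would track with bromo or with chloro.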